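This account rests on a few compounds, and the source may have more. Where it says the series, first, only, none or still open, it means among the compounds named here.

Measured so far:
compound 1, `COc1c(N2CCN(C/C(C)=N/NC(N)=O)C(C)C2)c(F)cc2c(=O)c(C(=O)O)cn(C3CC3)c12`: 500 ug/mL
compound 2, `COc1c(N2CCN(C/C(C)=N/Nc3ccccc3)C(C)C2)c(F)cc2c(=O)c(C(=O)O)cn(C3CC3)c12`: 11.1 ug/mL
compound 3, `COc1c(N2CCN(CC/C(C)=N/NC(N)=O)C(C)C2)c(F)cc2c(=O)c(C(=O)O)cn(C3CC3)c12`: 31.3 ug/mL

All three share one core and differ only in the side chain on the ring amine nitrogen. In an ADME assay on Vero cells (Chlorocebus sabaeus) for cytotoxicity, read by MTT assay, with a stated time of 72 h (on this read-out higher numbers stand for lower toxicity in this test and lower numbers for higher toxicity in this test), compound 1 gives 500 ug/mL. The change from compound 1 to compound 2 is phenyl in place of carbamoyl on an amine nitrogen and it gives a 45-fold lower number from compound 1 to compound 2 (1.65 log units; beyond the scatter). The change from compound 1 to compound 3 is a group of 8 heavy atoms (4 carbon, 3 nitrogen, 1 oxygen; no ring) in place of a group of 7 heavy atoms (3 carbon, 3 nitrogen, 1 oxygen; no ring), on a saturated chain carbon bound to an amine nitrogen in a ring and the cores of compounds 3 and 4 differ from that of compound 1 by exactly this; it gives a 16-fold lower number from compound 1 to compound 3 (1.20 log units; beyond the scatter). Between compound 2 and compound 3 the step is a 2.8-fold higher number from compound 2 to compound 3 (0.45 log units; beyond the scatter).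

Compound 4, `COc1c(N2CCN(CC/C(C)=N/Nc3ccccc3)C(C)C2)c(F)cc2c(=O)c(C(=O)O)cn(C3CC3)c12`, is not yet measured. It differs from compound 3 by phenyl in place of carbamoyl on an amine nitrogen, and the place given for this change is word for word the same as for the change from compound 1 to compound 2, so it is the same change, made once already among these compounds. Going by the values given here, since only one such step has been seen, there is no second instance to show whether its size carries over onto the longer chain. An expected step of about a 6.3-fold lower number from compound 3 to compound 4 (0.80 log units; beyond the scatter) is taken for compound 4, resting on the single precedent a 45-fold lower number from compound 1 to compound 2 (1.65 log units; beyond the scatter) and on the closeness of compound 2 and compound 3 shown by a 2.8-fold higher number from compound 2 to compound 3 (0.45 log units; beyond the scatter). On that basis compound 4 is estimated at 5 ug/mL, expected within 1.5 ug/mL to 15 ug/mL.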

Compound 4, half-maximal cytotoxic concentration: 62.5 ug/mL
Estimate against measurement, compound 4: 13-fold (1.10 log units) below; the whole stated range lies below it.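

Phenyl in place of carbamoyl on an amine nitrogen does not carry over as a fixed step from one core to the other in this assay: the same change on two cores in this assay, a 45-fold lower number (1.65 log units; beyond the scatter) from compound 1 to compound 2 and a 2.0-fold higher number (0.30 log units; within the scatter) from compound 3 to compound 4, 90-fold (1.95 log units) apart, beyond the scatter of two such steps

On the longer chain the change gives a 2.0-fold higher number from compound 3 to compound 4 (0.30 log units; within the scatter), which leaves no difference to read there; with phenyl kept, the longer chain gives a 5.6-fold higher number from compound 2 to compound 4 (0.75 log units; beyond the scatter), and with both changes together the step is an 8.0-fold lower number from compound 1 to compound 4 (0.90 log units; beyond the scatter). These two pairs show only that, in these four compounds, the size of the step depends on the chain that carries it; they give no rule for a further core, no reason for the gap, and no way of saying which of the two steps is the more usual one.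

Still open, as far as these compounds go, is whether the large step on the shorter chain or the absence of a readable step on the longer one would hold on a still longer chain. From the compounds shown here alone, it is also open whether another group on the same amine nitrogen, such as a thiocarbamoyl group or a pyridine ring in place of phenyl, would follow either pair, which would show whether the large step is specific to compound 1 and compound 2.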